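Swapping the N-aryl group on a pyridazinone amide

A few compounds are considered here, and "the series" means these few. Any claim that something is new, unique, unknown or untested is made for them only; others in the source may bear on it.

Measured so far:
compound 1 `Cc1cc(=O)n(-c2ccccc2C(F)(F)F)nc1C(=O)Nc1ccc(Oc2ncnc3c2ccn3C)cc1`, 19100 nM
compound 2 `Cc1cc(=O)n(-c2ccc(Br)cc2F)nc1C(=O)Nc1ccc(Oc2ncnc3c2ccn3C)c(F)c1`, 6670 nM
compound 3 `Cc1ccc(-n2nc(C(=O)Nc3ccc(Oc4ncnc5c4ccn5C)c(F)c3)c(C)cc2=O)cc1`, 50500 nM

In a functional assay on PC-3 cells (Homo sapiens) for cytotoxicity, read by MTT assay, with a stated time of 72 h (a lower number here means a stronger inhibitor, a higher number a weaker inhibitor), compound 3 gives the highest number of the three. The nearest is compound 1, and the furthest is compound 2, reached by a 7.6-fold higher number from compound 2 to compound 3 (0.88 log units; beyond the scatter). Compound 4 `Cc1cc(=O)n(-c2ccccc2C(F)(F)F)nc1C(=O)Nc1ccc(Oc2ncnc3c2ccn3C)c(F)c1` differs from compound 3 by 2-(trifluoromethyl)phenyl in place of 4-methylphenyl on an aromatic nitrogen. For the measured compounds named here, no measured step makes exactly this exchange; the step from compound 2 to compound 3 shows that changing this aryl group can move the number beyond the scatter, and compound 1, which carries the same 2-(trifluoromethyl)phenyl group, gives 19100 nM. A lower number is therefore expected for compound 4, by about a 3.6-fold lower number from compound 3 to compound 4 (0.56 log units; beyond the scatter). Compound 4 is estimated at 14000 nM, between 5000 nM and 40000 nM.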

Compound 4, half-maximal inhibitory concentration: 25900 nM
Estimate against measurement, compound 4: 1.9-fold (0.27 log units) below; the measured number falls inside the stated range.
By their numbers in this assay, from the lowest: compound 2; then compounds 1, 4 and 3 (each within the scatter of the next, the first and the last beyond it).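

In this assay, 2-(trifluoromethyl)phenyl in place of 4-methylphenyl on the aromatic nitrogen gives a 1.9-fold lower number from compound 3 to compound 4 (0.29 log units; within the scatter), so the assay does not separate these two groups, while 2-(trifluoromethyl)phenyl in place of 4-bromo-2-fluorophenyl gives a 3.9-fold higher number from compound 2 to compound 4 (0.59 log units; beyond the scatter), which sets 4-bromo-2-fluorophenyl apart from both. Fluoro in place of hydrogen on an aromatic carbon, with 2-(trifluoromethyl)phenyl kept, gives a 1.4-fold higher number from compound 1 to compound 4 (0.13 log units; within the scatter), so this change is not resolved either. Nothing at hand explains these differences.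

The compounds shown leave open whether the bromo or the fluoro of 4-bromo-2-fluorophenyl accounts for its separation. They also leave open what a phenyl group carrying an amine or a carboxylic acid would give on this nitrogen.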